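This account rests on a few compounds, and the source may have more. Where it says the series, first, only, none or still open, it means among the compounds named here.

In a functional assay on PC-3 cells (Homo sapiens) for inhibition (a lower number here means a stronger inhibitor, a higher number a weaker inhibitor), compound 1 `Cc1c(C(=O)N/N=C\c2ccc(O)cc2)oc2cccc(O)c12` gives 21700 nM and compound 2 `Cc1c(C(=O)N/N=C\c2cc(O)ccc2O)oc2cccc(O)c12` gives 95500 nM. Compound 3 `Cc1c(C(=O)N/N=C\c2ccncc2)oc2cccc(O)c12` gives >= 40000 nM, which is a limit of the assay rather than a measured number (the limit of >= 40000 nM in this assay, at which 1 of the 3 values shown sits). The step of an at least 1.8-fold higher number from compound 1 to compound 3 (0.26 log units; that floor lies within the scatter) has a floor that lies within the scatter, and the step that the limit leaves unreadable from compound 2 to compound 3 cannot be read at all. Compound 4 `Cc1c(C(=O)N/N=C\c2cccc(F)c2)oc2cccc(O)c12` differs from compound 3 by a single exchange: 3-fluorophenyl in place of pyridin-4-yl on a carbon with a double bond to nitrogen. For the measured compounds named here, none of the measured steps matches this exchange, and the starting point is itself a limit, so any expectation stays wide. For compound 4 the expected step is an at least 1.1-fold lower number from compound 3 to compound 4 (0.05 log units; that floor lies within the scatter), with the number estimated to fall between 12000 nM and 100000 nM, centred on 35000 nM.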

Compound 4, half-maximal inhibitory concentration: >= 40000 nM
Compound 4: no number, only a limit (the forecaster's own chance of this, stated with the estimate: 45%); middle value at least 1.1-fold (0.05 log units) away from the limit.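

In this assay compound 4 gives >= 40000 nM, which is a limit of the assay and not a number, and it is the second such result in this small set: the limit of >= 40000 nM in this assay, at which 2 of the 4 values shown sit. The steps from compound 2 and from compound 3 to this compound cannot be read. For the compounds shown here, the one readable step is an at least 1.8-fold higher number from compound 1 to compound 4 (0.26 log units; that floor lies within the scatter), so whether 3-fluorophenyl on this carbon truly trails 4-hydroxyphenyl stays unsettled.

Where compound 3 and compound 4 really lie beyond the limit stays open. So does how a 4-aminophenyl or a 4-carboxyphenyl group on this carbon would compare with 4-hydroxyphenyl.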